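The compounds below may be only part of what the source reports. "The series", "measured", "known", "first", "only" and "open" are said of these compounds alone.

Compound 1 `COc1cc(C)cc(-c2c(-c3ccnc(-c4ccc(C(C)=O)cc4)c3)cnn2CC#N)c1` is known in a functional assay on SK-OV-3 cells (Homo sapiens) for inhibition, read by sulforhodamine B assay, with a stated time of 48 h (a lower number here means that less compound is tolerated, a higher number that more compound is tolerated), only as a limit, > 100000 nM. Compound 2 `Cc1cc(O)cc(-c2nn(CC#N)cc2-c2ccnc(-c3ccc(Oc4ccccc4)cc3)c2)c1` gives in this assay a numerical value of 49600 nM. Compound 1 sits at the limit of > 100000 nM in this assay, at which 1 of the 2 values shown sits, so no number is known for it. Compound 3 `COc1cc(C)cc(-c2c(-c3ccnc(-c4ccc(N(C)C)cc4)c3)cnn2CC#N)c1` differs from compound 1 by dimethylamino in place of acetyl on an aromatic carbon. For the measured compounds named here, no measured step between two compounds is available to size this change, so for compound 3 the expected step from compound 1 is a number no higher from compound 1 to compound 3 (the limit leaves the size open), none beyond the scatter. Compound 3 is therefore estimated at 100000 nM, most likely again reported only as a limit, with a range of 40000 nM to 250000 nM.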

Compound 3, concentration lethal to 50% of the cells: > 100000 nM
Compound 3: no number, only a limit (the forecaster's own chance of this, stated with the estimate: 70%); the middle value sits exactly at the limit.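

For the compounds shown here, compound 1 and compound 3 are both known only as limits in this assay, so no step between them can be read. From the compounds shown here alone, whether dimethylamino in place of acetyl changes the lethal concentration at all remains open.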